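The compounds below may be only part of what the source reports. "The series", "measured", "known", "first", "only" and "open" are said of these compounds alone.

Two compounds from this series have been examined in a functional assay on MCF7 cells (Homo sapiens) for antiproliferative activity, read by MTT assay, with a stated time of 48 h, in the presence of a further agent that is not named here; a lower number here means a stronger inhibitor of growth, a higher number a weaker inhibitor of growth. Compound 1, `COc1ccc(-c2nn(-c3ccccc3)cc2C(=O)NOCc2ccccc2Cl)cc1`, gives 3730 nM in this assay. Compound 2, `O=C(NOCc1ccccc1F)c1cn(-c2ccccc2)nc1-c1ccc(F)cc1`, gives 12000 nM in this assay, which is the higher of the two numbers, and the gap to compound 1 lies beyond the scatter; the two structures differ at more than one place, so only their two values can be set side by side.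

Compound 3, `O=C(NOCc1ccccc1Cl)c1cn(-c2ccccc2)nc1-c1ccc(F)cc1`, is a closer relative of compound 2. It differs by chloro in place of fluoro on an aromatic carbon. For the measured compounds named here, no matched pair with this single change has been measured here, so the size of the step rests on expectation alone. Given that compound 1, which also carries the chlorobenzyl group, gives 3730 nM in this assay, compound 3 is expected to show a step of a 1.8-fold lower number from compound 2 to compound 3 (0.27 log units; within the scatter) toward a lower number, modest in size and possibly within the scatter. On that basis compound 3 is estimated at 6500 nM in this assay, within a range of 2500 nM to 16000 nM.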

Compound 3, concentration for 50% growth inhibition: 11400 nM
For compound 3 the middle estimate is 1.8-fold (0.24 log units) below the measured one; measured number inside the range.
By their numbers in this assay, from the lowest: compound 1; then compounds 3 and 2 (each within the scatter of the next).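

In this assay, chloro in place of fluoro on the benzyl group gives a 1.1-fold lower number from compound 2 to compound 3 (0.02 log units; within the scatter), so in this pair the change from 2-fluorobenzyl to 2-chlorobenzyl makes no difference that can be told from the scatter. With the 2-chlorobenzyl group held the same, fluoro in place of methoxy gives a 3.1-fold higher number from compound 1 to compound 3 (0.49 log units; beyond the scatter), a step beyond the scatter. Among these three compounds, the gap in growth inhibition therefore follows the change from methoxy to fluoro and not the halogen on the benzyl group, and nothing available here accounts for either result.

Going by these compounds, it remains open whether the halogen change would read the same in a compound that keeps the methoxy group. Also open, on these data alone, is how a bromo group, a methyl group or an amine in place of the chloro would behave.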